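Carbamoyl to Carboxy on a Shared Diketopiperazine-Free Core

This account rests on a few compounds, and the source may have more. Where it says the series, first, only, none or still open, it means among the compounds named here.

Compound 1 `CC(C)C[C@@H]1NC(=O)[C@H](CS)NC1=O` and compound 2 `CC(C)C[C@@H]1NC(=O)[C@H](CC(N)=O)NC1=O` share one core and differ only in one side chain. In a functional assay (on this read-out lower numbers stand for stronger inhibition and higher numbers for weaker inhibition), compound 1 gives 100000 nM, and compound 2 gives 170000 nM. Compound 2 has the highest of the two numbers, yet the step of a 1.7-fold higher number from compound 1 to compound 2 (0.23 log units; within the scatter) lies within the scatter, so nothing separates them. Compound 3 `CC(C)C[C@@H]1NC(=O)[C@H](CC(=O)O)NC1=O` differs from compound 2 by hydroxy in place of amino on a carbonyl carbon. Among the compounds with values here, no measured step touches this part of the molecule; the only known step, a 1.7-fold higher number from compound 1 to compound 2 (0.23 log units; within the scatter), was small. The expected step is a 1.1-fold lower number from compound 2 to compound 3 (0.05 log units; within the scatter), nothing beyond the scatter. Compound 3 is expected to give 150000 nM, within 60000 nM to 400000 nM.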

Compound 3, half-maximal inhibitory concentration: 4000 nM
Beside the measured number, compound 3's estimate is 38-fold (1.57 log units) above it; measured number outside the range, below it.
By their numbers in this assay, from the lowest: compound 3; then compounds 1 and 2 (each within the scatter of the next).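

In this assay this side chain proves able to move the number a long way: hydroxy in place of amino on a carbonyl carbon gives a 43-fold lower number from compound 2 to compound 3 (1.63 log units; beyond the scatter) and so sets carboxy apart from carbamoyl. Carboxy in place of sulfanyl gives a 25-fold lower number from compound 1 to compound 3 (1.40 log units; beyond the scatter) as well, so the carboxy compound stands clear of both earlier compounds, which the scatter could not separate. Nothing available explains this drop. The compounds shown leave open whether carboxy must sit on this short chain, or whether a longer chain ending in carboxy would serve equally well. On these data alone, how an amine at this position would compare also stays unknown.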